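Swapping the aryl group on a fused core

A few compounds are considered here, and "the series" means these few. Any claim that something is new, unique, unknown or untested is made for them only; others in the source may bear on it.

Compound 3 `O=S(=O)(c1cc(Cl)cc(Cl)c1)c1cnc2cc(F)ccc2c1-c1ccc(F)cc1` gives the lowest number of the three compounds in an ADME assay on microsomes from liver (Homo sapiens) for metabolic stability, tested at 2.5 uM (a lower number here means slower removal, a higher number faster removal of the compound), at 0.18 mL/min. Among the measured compounds shown here, compound 1 `O=S(=O)(c1cc(Cl)cc(Cl)c1)c1cnc2cc(F)ccc2c1-c1ccccc1F` gives 0.93 mL/min, and the step of a 5.2-fold lower number from compound 1 to compound 3 (0.71 log units; beyond the scatter) was the only single change seen so far. For the measured compounds named here, compound 2 `COc1cccc(-c2c(S(=O)(=O)c3ccc(C)c(C)c3)cnc3cc(F)ccc23)c1` gives 8.78 mL/min, but it differs from compound 3 in two places, so no single step links them. Compound 4 `COc1cccc(-c2c(S(=O)(=O)c3cc(Cl)cc(Cl)c3)cnc3cc(F)ccc23)c1` arises from compound 3 by the change (3-methoxyphenyl in place of 4-fluorophenyl on an aromatic carbon). Going by the values given here, no measured step covers this change directly; the only guide is that compound 2, which also carries the 3-methoxyphenyl, shows a far higher number in this assay than compound 3. The step of an 8.3-fold higher number from compound 3 to compound 4 (0.92 log units; beyond the scatter) is therefore expected to be upward, with wide uncertainty, giving compound 4 an estimated 1.5 mL/min within the range 0.4 mL/min to 5.5 mL/min.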

Compound 4, intrinsic clearance in a liver preparation (reported as CLH), per the amount of preparation that the assay uses: 1.51 mL/min
Estimate against measurement, compound 4: 1.0-fold (0.00 log units) below; measured number inside the range.
By their numbers in this assay, from the lowest: compound 3; then compounds 1 and 4 (each within the scatter of the next); then compound 2.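

In this assay, the aryl group at this position can shift the number: the 3-methoxyphenyl group gives an 8.4-fold higher number from compound 3 to compound 4 (0.92 log units; beyond the scatter) when it replaces 4-fluorophenyl, yet a 1.6-fold higher number from compound 1 to compound 4 (0.21 log units; within the scatter) when it replaces 2-fluorophenyl, so those two groups cannot be told apart here. The sulfonyl side also counts with 3-methoxyphenyl held fixed, as 3,5-dichlorophenyl in place of 3,4-dimethylphenyl gives a 5.8-fold lower number from compound 2 to compound 4 (0.76 log units; beyond the scatter) in the same assay. What an amine or a carboxylic acid on the aryl ring at this position would do remains open, and no measurement here gives a reason for any of these steps.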